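The source may report more compounds than this note shows. Statements on the series, on what has been measured and on what is new or still open speak of the compounds shown alone.

Measured compounds:
- compound 1, `CC(=O)N1CCC[C@H]1COCCCCCC/C=C/c1ccc(-c2ccccc2)cc1`: 50000 nM
- compound 2, `CC(=O)N1CCC[C@H]1COCCCCCCCCC/C=C/c1ccc(-c2ccccc2)cc1`: 56700 nM
- compound 3, `CC(C)(C)OC(=O)NCC(=O)N1CCC[C@H]1COCCCCCC/C=C/c1ccc(-c2ccccc2)cc1`: 66700 nM

All three numbers come from a functional assay on BXPC-3 cells (Homo sapiens) for inhibition, read by XTT assay, with a stated time of 72 h; a lower number here means a stronger inhibitor, a higher number a weaker inhibitor. The difference between the core of compound 1 and the core of compound 2 is not broken down here; their two values lie within the scatter of each other. From compound 1 to compound 3 the change is (tert-butoxycarbonyl)amino in place of hydrogen on a saturated chain carbon bound to a carbonyl carbon, and the step it made is a 1.3-fold higher number from compound 1 to compound 3 (0.13 log units; within the scatter).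

Compound 4, `CC(C)(C)OC(=O)NCC(=O)N1CCC[C@H]1COCCCCCCCCC/C=C/c1ccc(-c2ccccc2)cc1`, is not yet measured. It differs from compound 2 by (tert-butoxycarbonyl)amino in place of hydrogen on a saturated chain carbon bound to a carbonyl carbon, the same change as from compound 1 to compound 3, at the same place. Since that earlier step stayed within the scatter, the step from compound 2 to compound 4 is expected to be of the same order, a 1.2-fold higher number from compound 2 to compound 4 (0.09 log units; within the scatter), resting on the value of compound 2, 56700 nM, and on the earlier step of a 1.3-fold higher number from compound 1 to compound 3 (0.13 log units; within the scatter). Compound 4 is therefore estimated at 70000 nM in this assay, with a range of 35000 nM to 140000 nM.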

Compound 4, half-maximal inhibitory concentration: > 100000 nM
Compound 4: a limit, no number; the forecaster's own chance of this, stated with the estimate: 20%; at least 1.4-fold (0.15 log units) between middle value and limit.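

In this assay compound 4 gives > 100000 nM, which is a limit of the assay and not a number. Placing (tert-butoxycarbonyl)amino on the saturated chain carbon bound to a carbonyl carbon gives an at least 1.7-fold higher number from compound 2 to compound 4 (0.24 log units; that floor lies within the scatter), and set beside the earlier step the change reads: the same change on two cores in this assay, a 1.3-fold higher number (0.13 log units; within the scatter) from compound 1 to compound 3 and an at least 1.7-fold higher number (0.24 log units; that floor lies within the scatter) from compound 2 to compound 4; the limit leaves it open whether they differ This shows only that the change yields no stronger inhibitor beyond the scatter on either core; it does not show that the change carries from one core to the other with the same size, as the second step has a floor and no measured size.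

The compounds shown leave open whether a free amine in place of the (tert-butoxycarbonyl)amino would give a measurable number on either core. They also leave open whether a carboxylic acid in that place, or a longer chain than that of compound 4, would change the reading in this assay.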